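Swapping a ring oxygen for sulfur in a thiosemicarbazide

The source may hold more compounds than are shown below. What is called first, only, known or untested is meant among the compounds shown, and "the series" means these compounds.

Of the compounds shown here, two of this small series have been measured. Compound 1 `N/C(=N\NC(=S)N1CCOCC1)c1ccccn1` was tested in a functional assay on HeLa cells (Homo sapiens) for cytotoxicity, read by MTT assay, with a stated time of 72 h, tested at 3 uM (on this read-out lower numbers stand for less inhibition of growth and higher numbers for more inhibition of growth at the one concentration tested), where compound 1 gives 40%. Compound 2 `Cc1ccnc(/C(N)=N/NC(=S)N2CCOCC2)c1` carries a methyl in place of a hydrogen on an aromatic carbon, and in this assay compound 2 gives 44.7%. The step of a number 4.7 percentage points higher from compound 1 to compound 2 (within the scatter) is the only measured one, and it lies within the scatter, so compound 2 and compound 1 cannot be told apart on these numbers and neither stands out.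

Compound 3 `Cc1ccnc(/C(N)=N/NC(=S)N2CCSCC2)c1` keeps the methyl of compound 2 and differs only by thiomorpholin-4-yl in place of morpholin-4-yl on a thiocarbonyl carbon. Going by the values given here, no measured step touches this part of the molecule: the one known step, from compound 1 to compound 2, concerns the aromatic ring and was itself within the scatter. There is therefore no measured basis for a change in either direction in this assay. Compound 3 is expected to sit close to compound 2, with an estimated step of a number 0.3 percentage points higher from compound 2 to compound 3 (within the scatter). The estimate for compound 3 is 45%, with a range from 25% to 65%.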

Compound 3, percent growth inhibition at one concentration: 40.4%
The estimate for compound 3 lay 4.6 percentage points above the measured number; the range from low to high includes it.
By their numbers in this assay, from the lowest: compounds 1, 3 and 2 (each within the scatter of the next).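

Going by these compounds alone, the first measured step at this position, on a thiocarbonyl carbon, is a number 4.3 percentage points lower from compound 2 to compound 3 (within the scatter) in this assay. Sulfur can therefore stand in the ring in place of oxygen, with the ring size unchanged, and compound 3 still cannot be told apart from compound 2 on this read-out, so this exchange joins the methyl step on the aromatic carbon as a second change that gives no readable difference. No measurement shown here bears on the reason for this result.

From the compounds shown here alone, what remains open is whether this position can give a step beyond the scatter at all, since morpholin-4-yl and thiomorpholin-4-yl are close relatives that differ in a single ring atom. A piperazin-1-yl ring, which carries a nitrogen where these rings carry oxygen or sulfur, or an open-chain group such as diethylamino, would test the position with a much larger difference in structure and could show whether the ring itself matters for growth inhibition in these cells.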